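The source may report more compounds than this note shows. Statements on the series, on what has been measured and on what is new or still open speak of the compounds shown alone.

Measured compounds:
- Compound 1, `COc1cc(-c2cc(/C=C/C(=O)c3ccc(Cl)c(Cl)c3)[nH]n2)cc(OC)c1OC`: 92% in a functional assay on SF-268 cells (Homo sapiens) for cytotoxicity, read by sulforhodamine B assay, with a stated time of 48 h, tested at 0.01 uM; a lower number here means a stronger effect, a higher number a weaker effect of the compound at the concentration tested
- Compound 2, `COc1ccc(C(=O)/C=C/c2cc(-c3cc(OC)c(OC)c(OC)c3)n[nH]2)cc1`: 91% in this assay

Both compounds share the same core and differ only in the aromatic ring attached to the carbonyl carbon. On the numbers shown, compound 2 sits level with compound 1: the step of a number 1 percentage points lower from compound 1 to compound 2 (within the scatter) falls within the scatter, so the two readings cannot be told apart.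

Compound 3, `COc1cc(-c2cc(/C=C/C(=O)c3ccc(F)c(F)c3)[nH]n2)cc(OC)c1OC`, carries the same core as compound 2 with one alteration: 3,4-difluorophenyl in place of 4-methoxyphenyl on a carbonyl carbon.

For the measured compounds named here, the only measured step that bears on this change is the one at the same position, a number 1 percentage points lower from compound 1 to compound 2 (within the scatter), where exchanging one aromatic ring on the carbonyl carbon for another left the reading essentially unchanged. Compound 3 introduces a third ring at that same place, again a six-membered aromatic ring of carbon only, now with two fluorines. Going by the values given here, with only one comparison available, and that one showing no movement, the step of no change at the digits printed from compound 2 to compound 3 (within the scatter) is expected to stay within the scatter. Compound 3 is therefore estimated at 91% in this assay, with a range from 80% to 100%.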

Compound 3, a percentage reported as activity, at one concentration (the size of the read-out at that concentration, not a potency): 94%
Compound 3: middle estimate off by 3 percentage points, on the low side; low and high end bracket the measured number.
By their numbers in this assay, from the lowest: compounds 2, 1 and 3 (each within the scatter of the next).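

Within this assay putting 3,4-difluorophenyl in place of 4-methoxyphenyl on the carbonyl carbon gives a number 3 percentage points higher from compound 2 to compound 3 (within the scatter) and putting it in place of 3,4-dichlorophenyl gives a number 2 percentage points higher from compound 1 to compound 3 (within the scatter) so this third ring cannot be told apart from the other two. For the compounds shown here, the earlier pair offered only one comparison at this place, whereas three rings carrying methoxy, chlorine or fluorine now give three comparisons, and none of the steps among them lies beyond the scatter. Nothing measured alongside these readings offers an explanation for why the three rings read alike.

As far as these compounds go, all three groups are six-membered aromatic rings of carbon only, so it stays open whether something of another kind on the carbonyl carbon, such as a carboxylic acid or a longer chain ending in an amine, would move the reading beyond the scatter. The shared core is also identical throughout, which leaves open what a change elsewhere in it would do, and whether these rings would still read alike at a different concentration.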